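Benzyloxy on the Pendant Phenyl of a Dichalcone

The source may hold more compounds than are shown below. What is called first, only, known or untested is meant among the compounds shown, and "the series" means these compounds.

In a functional assay on MCF7 cells (Homo sapiens) for cytotoxicity, read by MTT assay, with a stated time of 24 h (on this read-out higher numbers stand for weaker inhibition and lower numbers for stronger inhibition), compound 1, with the structure `Cc1cc(O)c(C(=O)/C=C/c2ccccc2)c(-c2ccccc2)c1C(=O)/C=C/c1ccccc1`, gives 10000 nM. Compound 3, the structure `Cc1cc(O)c(C(=O)/C=C/c2ccc(F)cc2)c(-c2ccc(Br)cc2)c1C(=O)/C=C/c1ccc(F)cc1`, gives 20000 nM in this assay, and the two numbers lie within the usual scatter of each other, so neither can be placed above the other. Compound 2, the structure `COc1ccc(/C=C/C(=O)c2c(C)cc(O)c(C(=O)/C=C/c3ccc(OC)c(OC)c3)c2-c2ccccc2)cc1OC`, was reported in this assay as "not active" (no number reported), with no number attached. Against this background compound 1 is the starting point for a single change. Compound 4, the structure `Cc1cc(O)c(C(=O)/C=C/c2ccccc2)c(-c2ccc(OCc3ccccc3)cc2)c1C(=O)/C=C/c1ccccc1`, differs from compound 1 by benzyloxy in place of hydrogen on an aromatic carbon.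

Among the compounds with values here, no pair among the measured compounds shows a single-site step of this kind, so there is nothing to say about how such a change has moved the numbers before. Within the data shown here, the only guidance is that the two measured numbers, from compound 1 and compound 3, sit within the scatter of each other, and that compound 2 gave no number at all. On that basis the step from compound 1 to compound 4 is expected to be no change at the digits printed from compound 1 to compound 4 (within the scatter), that is, no movement beyond the scatter in either direction. For compound 4 the estimated value in this assay is 10000 nM, with a range from 3000 nM to 40000 nM.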

Compound 4, half-maximal inhibitory concentration: "not active" (no number reported)
Compound 4: no number reported; the estimate stays without a comparison.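

Within the data shown here, compound 4 carries no number in this assay, so no step from compound 1 to compound 4 can be read. The compounds shown leave open how benzyloxy in place of hydrogen on the pendant phenyl affects the number in this assay. Nothing further in the data bears on this result.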